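Methyl on the ring carbon: compound 3 to compound 4

The compounds below may be only part of what the source reports. "The series", "measured", "known", "first", "only" and "open" are said of these compounds alone.

The series shares a thiosemicarbazide-linked amidine core with a cyclic amine on the thiocarbonyl carbon. In a functional assay on A-431 cells (Homo sapiens) for cytotoxicity, read by MTT assay, with a stated time of 72 h (a higher number here means a weaker inhibitor, a lower number a stronger inhibitor), compound 1 `Cc1ccnc(/C(N)=N/NC(=S)N2CCOCC2)c1` gives 6800 nM, compound 2 `Cc1ccnc(/C(N)=N/NC(=S)N2CCSCC2)c1` gives 7200 nM and compound 3 `N/C(=N\NC(=S)N1CCCCC1)c1ccccn1` gives 6900 nM. Compound 3 stands second highest of the three numbers, with compound 1 nearest and compound 2 furthest, all three within the scatter of one another.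

Compound 4 `Cc1ccnc(/C(N)=N/NC(=S)N2CCCCC2)c1` has not been measured. It differs from compound 3 by methyl in place of hydrogen on an aromatic carbon, on an aromatic carbon of a six-membered aromatic ring with 1 nitrogen, meta to a large group and opposite the ring nitrogen.

Among the compounds with values here, the only measured step, a 1.1-fold higher number from compound 1 to compound 2 (0.02 log units; within the scatter), varies the cyclic amine and not the ring methyl, so it does not bear on this change directly. Compound 1 carries the methyl and compound 3 does not, but they also differ in the amine ring, and their values in this assay sit within the scatter. Within the data shown here, no measured pair isolates the methyl. The expectation is therefore a step of a 1.0-fold higher number from compound 3 to compound 4 (0.01 log units; within the scatter), nothing beyond the scatter. Compound 4 is estimated at 7000 nM, between 3500 nM and 14000 nM.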

Compound 4, half-maximal inhibitory concentration: 18900 nM
For compound 4 the middle estimate is 2.7-fold (0.43 log units) below the measured one; measured number outside the range, above it.
By their numbers in this assay, from the lowest: compounds 1, 3 and 2 (each within the scatter of the next); then compound 4.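

Within the data shown here, the ring carbon opposite the ring nitrogen is not a silent position: in this assay, methyl in place of hydrogen on the piperidin-1-yl compounds gives a step beyond the scatter (a 2.7-fold higher number from compound 3 to compound 4 (0.44 log units; beyond the scatter)), the first such step. With the methyl held constant, the amine ring also matters, since piperidin-1-yl gives a weaker compound than thiomorpholin-4-yl (a 2.6-fold higher number from compound 2 to compound 4 (0.42 log units; beyond the scatter)) or morpholin-4-yl (a 2.8-fold higher number from compound 1 to compound 4 (0.44 log units; beyond the scatter)), while the change between those last two stays within the scatter (a 1.1-fold higher number from compound 1 to compound 2 (0.02 log units; within the scatter)). Compound 4 is therefore the weakest of the four, and nothing at hand accounts for either modest step.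

From the compounds shown here alone, the methyl step is read on the piperidin-1-yl compounds alone, so it remains open whether the same change carries the same penalty with morpholin-4-yl or thiomorpholin-4-yl on the thiocarbonyl carbon. Going by these compounds, it is also open how this ring carbon responds to groups other than methyl, such as ethyl, methoxy, chlorine or a carboxylic acid, and so whether the loss follows from methyl specifically or from any replacement of the hydrogen.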